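Para-methyl on the phenyl: working notes for compound 4

The source may hold more compounds than are shown below. What is called first, only, known or untested is meant among the compounds shown, and "the series" means these compounds.

Measured compounds:
- compound 1, `O=C(c1ccc2c(c1)ncn2-c1ccccc1)N1CCCCC1`, 22 nM
- compound 2, `O=C(c1ccc2c(c1)ncn2-c1cccc(C(F)(F)F)c1)N1CCCCC1`, 48 nM
- compound 3, `CC(C)c1cccc(-n2cnc3cc(C(=O)N4CCCCC4)ccc32)c1`, 68 nM

In an assay on isolated protein for inhibition of 15-hydroxyprostaglandin dehydrogenase [NAD(+)] (Homo sapiens), read by fluorescence, with a stated time of 15 min (on this read-out lower numbers stand for stronger inhibition and higher numbers for weaker inhibition), compound 1 gives the lowest of the three numbers; compound 2 is the nearest and compound 3 the furthest from it. Both measured steps away from compound 1 place a group on the phenyl ring and both raise the number: a 2.2-fold higher number from compound 1 to compound 2 (0.34 log units; beyond the scatter) and a 3.1-fold higher number from compound 1 to compound 3 (0.49 log units; beyond the scatter). Between those two substituted compounds the difference is small, a 1.4-fold higher number from compound 2 to compound 3 (0.15 log units; within the scatter).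

Compound 4, `Cc1ccc(-n2cnc3cc(C(=O)N4CCCCC4)ccc32)cc1`, is not yet measured in this assay. Its change from compound 1 is methyl in place of hydrogen on an aromatic carbon; it sits on an aromatic carbon of a six-membered aromatic ring of carbon only, para to a large group, so the substituted phenyl now reads 4-methylphenyl. The steps from compound 1 to compound 2 and from compound 1 to compound 3 bear on it, as they also add a group to the phenyl, though at a different place and with bigger groups. Methyl is the smallest of the three additions, so a smaller rise is expected, and the step from compound 1 to compound 4 is estimated at a 1.6-fold higher number from compound 1 to compound 4 (0.20 log units; within the scatter), possibly within the scatter. Compound 4 is therefore expected to give about 35 nM, with a range from 15 nM to 90 nM.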

Compound 4, half-maximal inhibitory concentration: 19 nM
The estimate for compound 4 lay 1.8-fold (0.27 log units) above the measured number, within the range that was stated.
By their numbers in this assay, from the lowest: compounds 4 and 1 (each within the scatter of the next); then compounds 2 and 3 (each within the scatter of the next).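

In this assay, methyl on the aromatic carbon para to a large group leaves the number of compound 1 effectively unchanged, with a 1.2-fold lower number from compound 1 to compound 4 (0.06 log units; within the scatter) as the step, so this is the first addition to the phenyl shown that stays within the scatter. The other two additions, a 2.2-fold higher number from compound 1 to compound 2 (0.34 log units; beyond the scatter) and a 3.1-fold higher number from compound 1 to compound 3 (0.49 log units; beyond the scatter), lie beyond the scatter, so the phenyl of compound 1 does not respond to every added group in the same way. No measurement here gives a reason for this difference between the steps.

Because compound 4 differs from compounds 2 and 3 in both the group and its place, the compounds shown cannot separate the effect of the group from the effect of its place: methyl at the place used in compounds 2 and 3, and trifluoromethyl or isopropyl para to a large group, would be needed to do so. Also open, on these data alone, is how far this position accepts other groups, such as an amine, a carboxylic acid or a longer chain.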